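The compounds below may be only part of what the source reports. "The series", "measured", "known", "first", "only" and "open" are said of these compounds alone.

Two measured compounds share one core and differ only in how a dichlorinated ring is attached to it. Compound 1 `Nc1cc(N)c2nc(-c3ccccc3)c(NCc3ccc(Cl)c(Cl)c3)nc2c1` and compound 2 `Nc1cc(N)c2nc(-c3ccccc3)c(Sc3ccc(Cl)c(Cl)c3)nc2c1` were both tested in a functional assay on NCI-H322M cells (Homo sapiens) for inhibition, read by sulforhodamine B assay, with a stated time of 48 h; on this read-out higher numbers stand for weaker inhibition of growth and lower numbers for stronger inhibition of growth. In this assay compound 1 gives 30200 nM, and compound 2 gives 35500 nM. Going by the values given here, these two numbers lie within the usual scatter of each other, so compound 1 cannot be set apart from compound 2 on this read-out; it simply stands alongside the only other measured compound.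

Compound 3 `COc1ccc(CNc2nc3cc(N)cc(N)c3nc2-c2ccccc2)cc1` has not yet been measured. It differs from compound 1 in one place: 4-methoxyphenyl in place of 3,4-dichlorophenyl on a saturated chain carbon bound to a nitrogen on an aromatic ring. Among the compounds with values here, no measured pair shows what this particular change does, so the expectation has to rest on the number that compound 1 gives, 30200 nM, and on the fact that the two measured compounds sit close together. Compound 3 is expected to give about 40000 nM, with a range from 15000 nM to 110000 nM. The expected step of a 1.3-fold higher number from compound 1 to compound 3 (0.12 log units; within the scatter) is small, with no firm direction and not beyond the scatter.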

Compound 3, concentration for total growth inhibition: 52500 nM
Compound 3: the middle estimate sits 1.3-fold (0.12 log units) below what was measured; measured number inside the range.
By their numbers in this assay, from the lowest: compounds 1, 2 and 3 (each within the scatter of the next).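

Compound 1 and compound 2 differ only in how the dichlorinated ring is attached, whereas compound 3 is the first shown to change what the ring itself carries. In this assay, replacing 3,4-dichlorophenyl with 4-methoxyphenyl on a saturated chain carbon bound to a nitrogen on an aromatic ring gives a 1.7-fold higher number from compound 1 to compound 3 (0.24 log units; within the scatter), so this exchange of both chlorine atoms for a group with one hydrogen-bond acceptor, at an equal count of heavy atoms, does not separate the two compounds on this read-out. No supporting information bears on why the number stays within the scatter, so the result describes this one pair and gives no explanation for it.

With both the chlorine atoms and the methoxy group changing at once, the compounds shown leave open what each change would do alone, for example with a single chlorine or a methoxy group paired with a chlorine on the same ring. They also leave open whether a more different group at this position, such as a carboxylic acid or an amine on the ring, or a longer chain leading to it, would move the number beyond the scatter.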